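The compounds below may be only part of what the source reports. "The series", "measured", "known", "first", "only" and "open" are said of these compounds alone.

Measured in a functional assay on MCF7 cells (Homo sapiens) for antiproliferative activity, read by CellTiter-Glo, with a stated time of 5 days; on this read-out lower numbers stand for stronger inhibition and higher numbers for weaker inhibition:
- compound 1 `CC/C(=C(/c1ccc(/C=C/C(=O)O)cc1)c1ccc2c(cnn2C)c1)c1ccccc1`: 300 nM
- compound 2 `CC/C(=C(/c1ccc(/C=C/C(=O)O)cc1)c1ccc2scnc2c1)c1ccccc1`: 90 nM

Of these two numbers, the lower belongs to compound 2, at 90 nM. The next step leads to compound 3 `CC/C(=C(/c1ccc(/C=C/C(=O)O)cc1)c1ccc2sc(C)nc2c1)c1ccccc1`, with the change (methyl in place of hydrogen on an aromatic carbon). This is methyl in place of hydrogen on an aromatic carbon, next to the ring nitrogen and next to the ring sulfur, turning 1,3-benzothiazol-5-yl into 2-methyl-1,3-benzothiazol-5-yl.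

For the measured compounds named here, only one measured step bears on this: a 3.3-fold lower number from compound 1 to compound 2 (0.52 log units; beyond the scatter). It is a modest step, and it exchanges the whole 1-methyl-1H-indazol-5-yl group for 1,3-benzothiazol-5-yl. Going by the values given here, the new change alters that same group, but only by adding a methyl, and no measured pair shows what such an addition does. Among the compounds with values here, with a 3.3-fold lower number from compound 1 to compound 2 (0.52 log units; beyond the scatter) as the only guide, a smaller step is expected in this assay, probably not beyond the scatter. The data set no direction, so only a slight lean towards a higher number is assumed. The estimate amounts to an expected 1.2-fold higher number from compound 2 to compound 3 (0.09 log units; within the scatter). For compound 3 the expected value is 110 nM, with an estimated range of 40 nM to 300 nM.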

Compound 3, half-maximal inhibitory concentration: > 500 nM
Compound 3 gave a limit, no number (the forecaster's own chance of this, stated with the estimate: 2%); at least 4.5-fold (0.65 log units) between middle value and limit.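

In this assay compound 3 is recorded as a limit and not a number: the limit of > 500 nM in this assay, at which 1 of the 3 values shown sits. For the compounds shown here, this is the first read on a single small addition, and methyl in place of hydrogen on the aromatic carbon next to the ring nitrogen and next to the ring sulfur is far from silent (an at least 5.5-fold higher number from compound 2 to compound 3 (0.74 log units; beyond the scatter)), so this position responds strongly to a change of a single heavy atom. The step from the 1-methyl-1H-indazol-5-yl group to 2-methyl-1,3-benzothiazol-5-yl (an at least 1.6-fold higher number from compound 1 to compound 3 (0.22 log units; that floor lies within the scatter)) has a floor within the scatter, so the advantage of 1,3-benzothiazol-5-yl (a 3.3-fold lower number from compound 1 to compound 2 (0.52 log units; beyond the scatter)) does not survive the methyl, although compound 1 and compound 3 are not clearly separated.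

On these data alone, the full size of the loss stays open, as does whether it is specific to methyl, since only hydrogen and methyl appear at this position and a fluorine, an amine or a longer chain such as ethyl could read differently. As far as these compounds go, it is also open whether the same methyl penalty would hold with an amide in place of the carboxylic acid on the shared core.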